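The compounds below may be only part of what the source reports. "The series", "measured", "known", "first", "only" and "open" are said of these compounds alone.

Measured so far:
- compound 2, `COc1cc2ncnc(NCc3cccc(NC(=O)Nc4ccccc4C)c3)c2cc1OC`, gives 21400 nM in a functional assay on A549 cells (Homo sapiens) for antiproliferative activity, read by MTT assay; a higher number here means a weaker inhibitor, a lower number a stronger inhibitor
- compound 1, `COc1ccccc1NC(=O)Nc1cccc(CNc2ncnc3ccccc23)c1`, gives 30800 nM in this assay

Both numbers are high, so both compounds are weak inhibitors of cell growth in this assay. For the measured compounds named here, compound 2 and compound 1 lie within the usual scatter of each other, so neither can be called the stronger of the two; the data give no step at all that has been measured between compounds differing in a single place, and so no guide to how large a change at the urea end can be.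

Compound 3, `COc1cc2ncnc(NCc3cccc(NC(=O)Nc4ccc(Cl)cc4)c3)c2cc1OC`, is the next compound. It differs from compound 2 in one place: 4-chlorophenyl in place of 2-methylphenyl on an amide-type nitrogen. Going by the values given here, with no measured step to lean on, the expectation is a modest shift, if any, in this assay, and a step from compound 2 to compound 3 of a 1.3-fold lower number from compound 2 to compound 3 (0.13 log units; within the scatter) is expected, possibly no larger than the scatter. Compound 3 is therefore estimated at 16000 nM, with a range from 5000 nM to 50000 nM.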

Compound 3, half-maximal inhibitory concentration: 30400 nM
Compound 3: middle estimate off by 1.9-fold (0.28 log units), on the low side, within the range that was stated.
By their numbers in this assay, from the lowest: compounds 2, 3 and 1 (each within the scatter of the next).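

For the compounds shown here, this is the first measured step at this end of the molecule: in this assay, 4-chlorophenyl in place of 2-methylphenyl on an amide-type nitrogen gives a 1.4-fold higher number from compound 2 to compound 3 (0.15 log units; within the scatter). The two groups have the same count of heavy atoms and each is one six-membered aromatic ring of carbon only, so this exchange of a methyl-bearing ring for a chlorine-bearing one leaves the two compounds indistinguishable, and both remain weak inhibitors. Nothing measured here offers an explanation for this result.

Going by these compounds, it remains open whether an amine or a carboxylic acid on this phenyl ring, or a longer chain in place of the ring, would give a step beyond the scatter. Also open, on these data alone, is how 4-chlorophenyl would read on the core of compound 1.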